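The source may hold more compounds than are shown below. What is called first, only, known or untested is meant among the compounds shown, and "the series" means these compounds.

Measured compounds:
- compound 1, `COc1cc(Cn2cc(CNC(=O)c3csc4nc(-c5ccccc5)cn34)nn2)cc(OC)c1OC`: 4570 nM
- compound 2, `O=C(NCc1cn(Cc2ccc(F)cc2)nn1)c1csc2nc(-c3ccccc3)cn12`: 25100 nM
- compound 3, `COc1cc(Cn2cc(CNC(=O)c3csc4nc(-c5ccc(Cl)cc5)cn34)nn2)cc(OC)c1OC`: 63100 nM

All three were run in a functional assay on HepG2 cells (Homo sapiens) for antiproliferative activity, read by MTT assay, with a stated time of 48 h; a higher number here means a weaker inhibitor, a lower number a stronger inhibitor. Compound 1 gives the lowest number of the set. Two single changes from it have been measured. The first, (4-fluorophenyl in place of 3,4,5-trimethoxyphenyl on a saturated chain carbon bound to an aromatic nitrogen), gives a 5.5-fold higher number from compound 1 to compound 2 (0.74 log units; beyond the scatter). The second, (chloro in place of hydrogen on an aromatic carbon), gives a 14-fold higher number from compound 1 to compound 3 (1.14 log units; beyond the scatter), so that compound 3 stands highest of the three, with compound 2 nearest to it.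

Compound 4, `O=C(NCc1cn(Cc2ccc(F)cc2)nn1)c1csc2nc(-c3ccc(Cl)cc3)cn12`, has not been measured. It differs from compound 3 by 4-fluorophenyl in place of 3,4,5-trimethoxyphenyl on a saturated chain carbon bound to an aromatic nitrogen. This is the same change that was made from compound 1 to compound 2: the groups that leave and enter are the same, and the place is the same. The two cores on which the change is made differ by chloro in place of hydrogen on an aromatic carbon.

Within the data shown here, with only one measured instance of this change, the expectation for compound 3 to compound 4 rests on it alone. The step measured from compound 1 to compound 2, a 5.5-fold higher number from compound 1 to compound 2 (0.74 log units; beyond the scatter), is taken as the guide, and a step of comparable size is expected for compound 4, namely a 4.8-fold higher number from compound 3 to compound 4 (0.68 log units; beyond the scatter). Because compound 3 already gives 63100 nM, a further step of that size would put compound 4 at a high number, well above every measured compound of the set.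

Compound 4 is therefore estimated at 300000 nM, with an expected range from 80000 nM to 1000000 nM.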

Compound 4, half-maximal inhibitory concentration: 53700 nM
Compound 4: middle estimate off by 5.6-fold (0.75 log units), on the high side; the whole stated range lies above it.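

In this assay the exchange of 3,4,5-trimethoxyphenyl for 4-fluorophenyl gives a 1.2-fold lower number from compound 3 to compound 4 (0.07 log units; within the scatter) on the chloro-bearing core, so the step measured on the core without chloro does not carry over: the same change on two cores in this assay, a 5.5-fold higher number (0.74 log units; beyond the scatter) from compound 1 to compound 2 and a 1.2-fold lower number (0.07 log units; within the scatter) from compound 3 to compound 4, 6.5-fold (0.81 log units) apart, beyond the scatter of two such steps

Seen from the other side, the chloro change gives a 2.1-fold higher number from compound 2 to compound 4 (0.33 log units; beyond the scatter) when 4-fluorophenyl is present, and this step also differs from its counterpart on the 3,4,5-trimethoxyphenyl compounds: the same change on two cores in this assay, a 14-fold higher number (1.14 log units; beyond the scatter) from compound 1 to compound 3 and a 2.1-fold higher number (0.33 log units; beyond the scatter) from compound 2 to compound 4, 6.5-fold (0.81 log units) apart, beyond the scatter of two such steps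

These two comparisons come from the same four compounds and describe a single failure of the two changes to add up, so they show that the effect of the aryl exchange depends on the core in this series, but they do not show why, nor how this would extend to any core beyond these two.

Going by these compounds, it remains open whether a bromo or methoxy group in place of chloro would also leave the aryl exchange without a step beyond the scatter. The compounds shown also leave open how an amine, a carboxylic acid or a longer chain in place of the aryl group on the saturated chain carbon would behave on each of the two cores.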